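The compounds below may be only part of what the source reports. "The series", "measured", "known", "first", "only" and "open" are said of these compounds alone.

Measured compounds:
compound 1, `CCOC(=O)N(Cc1ccccc1C(C)C)[C@H]1CCNC1`, 3340 nM in an assay on HEK293 cells for inhibition of sodium-dependent dopamine transporter (Homo sapiens); on this read-out higher numbers stand for weaker inhibition and lower numbers for stronger inhibition
compound 2, `CC(C)S(=O)(=O)N(Cc1ccccc1-c1ccccc1)[C@H]1CCNC1`, 2700 nM in this assay

Among the compounds with values here, only two compounds carry a number in this assay. Compound 2 gives 2700 nM, and compound 1 gives 3340 nM; the two values lie within the scatter of each other, so neither compound can be placed ahead of the other, and compound 2 stands on level ground with compound 1 on the numbers shown. Within the data shown here, no structural step between the measured compounds is available, since they differ in more than one place.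

Compound 3, `CN(C)C(=O)N(Cc1ccccc1-c1ccccc1)[C@H]1CCNC1`, has not yet been measured in this assay. It differs from compound 2 in one place: dimethylcarbamoyl in place of isopropylsulfonyl on an amine nitrogen. Nothing in the two measured values tells how this exchange will play out, and the range spanned by compound 1 and compound 2 is narrow. A step from compound 2 to compound 3 of a 1.3-fold higher number from compound 2 to compound 3 (0.11 log units; within the scatter) is expected, that is, no change beyond the scatter, with a small lean toward a weaker value. Compound 3 is accordingly estimated at 3500 nM in this assay, within a range from 1200 nM to 10000 nM.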

Compound 3, inhibition constant: 2970 nM
Compound 3: middle estimate off by 1.2-fold (0.07 log units), on the high side, within the range that was stated.
By their numbers in this assay, from the lowest: compounds 2, 3 and 1 (each within the scatter of the next).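

In this assay, putting dimethylcarbamoyl in place of isopropylsulfonyl on the amine nitrogen gives a 1.1-fold higher number from compound 2 to compound 3 (0.04 log units; within the scatter). Within the data shown here, this is the first step that differs in one place, and it isolates this nitrogen substituent with the rest of the compound held fixed, which the earlier comparison of compound 1 and compound 2 could not do. For this pair, a sulfonyl link and a carbonyl link on the nitrogen cannot be told apart on this read-out, although the two groups differ in their atoms, their double bonds and their hydrogen-bond acceptors, and no measurement shown here offers an account of that result.

The compounds shown leave open whether this holds only for these two groups or also for others on the same nitrogen, such as an acetyl group, a benzoyl group or a longer chain on the sulfonyl, and whether any group there moves the number beyond the scatter. They also leave open what a different group on the aromatic ring would do with the nitrogen substituent held fixed, for instance a methoxy group or a chlorine atom.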